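This account rests on a few compounds, and the source may have more. Where it says the series, first, only, none or still open, it means among the compounds named here.

Measured so far:
compound 1 `C[C@@H](NC(=O)[C@H](CCCNC(=N)N)NC(=O)c1ccc(CN(Cc2ccncc2)Cc2ccc(F)cc2)cc1)c1cccc2ccccc12`: 39000 nM
compound 2 `C[C@@H](NC(=O)[C@H](CCCNC(=N)N)NC(=O)c1ccc(CN(Cc2cccnc2)C(=O)c2ccc(F)cc2)cc1)c1cccc2ccccc12`: 45000 nM

Both numbers come from an ADME assay on MT4 cells (Homo sapiens) for cytotoxicity; a higher number here means that more compound is tolerated, a lower number that less compound is tolerated. Of the two, compound 2 gives the higher one, but its gap to compound 1 lies within the scatter, so no order between them is claimed. Compound 3 `C[C@@H](NC(=O)[C@H](CCCNC(=N)N)NC(=O)c1ccc(CN(Cc2ccncc2)C(=O)c2ccc(F)cc2)cc1)c1cccc2ccccc12` is not yet measured. From compound 2 it differs in one place: pyridin-4-yl in place of pyridin-3-yl on a saturated chain carbon bound to an amide-type nitrogen. Among the measured compounds shown here, no measured pair shows the effect of this change. A step not beyond the scatter is expected, in either direction. Compound 3 is therefore estimated at 45000 nM, with a range from 22000 nM to 90000 nM. The step expected in this assay is no change at the digits printed from compound 2 to compound 3 (within the scatter).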

Compound 3, half-maximal cytotoxic concentration: 45000 nM
Estimate against measurement, compound 3: no gap at the digits printed, within the range that was stated.
By their numbers in this assay, from the lowest: compounds 1, 2 and 3 (each within the scatter of the next).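

In this assay, pyridin-4-yl in place of pyridin-3-yl on a saturated chain carbon bound to an amide-type nitrogen gives no change at the digits printed from compound 2 to compound 3 (within the scatter), so this change of pyridine isomer has no readable effect here. (4-Fluorophenyl)carbonyl in place of 4-fluorobenzyl on an amine nitrogen gives a 1.2-fold higher number from compound 1 to compound 3 (0.06 log units; within the scatter), which also stays within the scatter. No measurement at hand accounts for either step. Open, on these data alone, is whether pyridin-2-yl or plain phenyl at the first place, or a sulfonyl group in place of the carbonyl at the second, would shift the number beyond the scatter.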